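A Carbonyl Substituent Swap on the Shared Core

A few compounds are considered here, and "the series" means these few. Any claim that something is new, unique, unknown or untested is made for them only; others in the source may bear on it.

Compound 1 `COc1ccc(-c2cnc3nc(N)nc(N4CCN(Cc5ccccc5F)CC4)c3n2)cc1OC` gives 700 nM in a functional assay on cells (T-cell, Homo sapiens) for inhibition; a lower number here means a stronger inhibitor, a higher number a weaker inhibitor. Compound 2 `COc1ccc(-c2cnc3nc(N)nc(N4CCN(C(=O)CCc5ccccc5)CC4)c3n2)cc1OC` gives 100 nM in this assay, and the step of a 7.0-fold lower number from compound 1 to compound 2 (0.85 log units; beyond the scatter) leaves compound 2 with the lower of the two numbers. Compound 3 `COc1ccc(-c2cnc3nc(N)nc(N4CCN(C(=O)NCc5ccc(F)cc5)CC4)c3n2)cc1OC` differs from compound 2 by (4-fluorobenzyl)amino in place of phenethyl on a carbonyl carbon. Among the compounds with values here, only the step of a 7.0-fold lower number from compound 1 to compound 2 (0.85 log units; beyond the scatter) bears on this change, and it replaced the whole group on the ring nitrogen rather than just the part beyond the carbonyl, so it guides only loosely. A step within the scatter, or a small rise, is expected, a 1.6-fold higher number from compound 2 to compound 3 (0.20 log units; within the scatter). Compound 3 is therefore estimated at 160 nM, between 50 nM and 500 nM.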

Compound 3, half-maximal inhibitory concentration: 37 nM
Compound 3: the middle estimate sits 4.3-fold (0.64 log units) above what was measured; measured number outside the range, below it.
By their numbers in this assay, from the lowest: compound 3; then compound 2; then compound 1.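

In this assay the change beyond the carbonyl alone, (4-fluorobenzyl)amino in place of phenethyl, brings a 2.7-fold lower number from compound 2 to compound 3 (0.43 log units; beyond the scatter) and so shows that this part of the group matters on its own. The full change on the ring nitrogen gives a 19-fold lower number from compound 1 to compound 3 (1.28 log units; beyond the scatter) and is the largest step among these compounds. Nothing given here accounts for these gains.

As far as these compounds go, the amide hydrogen and the fluorine enter together, so their separate shares stay open. An unsubstituted benzylcarbamoyl, or a longer chain before the ring, would help to separate them.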